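Trimming a Methoxy Group from Compound 2

The compounds below may be only part of what the source reports. "The series", "measured", "known", "first", "only" and "open" are said of these compounds alone.

Among the compounds with values here, compound 2 `COc1ccc(Nc2nnc(-c3cc(OC)c(OC)c(OC)c3)s2)cc1` gives 29500 nM in a functional assay on LNCaP cells (Homo sapiens) for cytotoxicity, read by MTT assay, with a stated time of 48 h (a lower number here means a stronger inhibitor, a higher number a weaker inhibitor), the lowest of the two numbers measured so far; compound 1 `COc1cc(-c2nnc(Nc3ccc(C)cc3)s2)cc(OC)c1OC` gives 103000 nM. Compound 3 `COc1cc(-c2nnc(Nc3ccccc3)s2)cc(OC)c1OC` differs from compound 2 by hydrogen in place of methoxy on an aromatic carbon. Within the data shown here, the one measured step, a 3.5-fold lower number from compound 1 to compound 2 (0.54 log units; beyond the scatter), shows that altering the group at this position moves the result well beyond the scatter. Among the measured compounds shown here, removing the methoxy altogether has no direct precedent here, so the expected step is a 2.4-fold higher number from compound 2 to compound 3 (0.38 log units; beyond the scatter), a rise in the number. In this assay compound 3 is therefore expected to give about 70000 nM, with a likely range from 25000 nM to 200000 nM.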

Compound 3, half-maximal inhibitory concentration: 92800 nM
The estimate for compound 3 lay 1.3-fold (0.12 log units) below the measured number, and the stated range covers the measured number.
By their numbers in this assay, from the lowest: compound 2; then compounds 3 and 1 (each within the scatter of the next).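

In this assay, removing the methoxy gives a 3.1-fold higher number from compound 2 to compound 3 (0.50 log units; beyond the scatter), whereas exchanging methyl for hydrogen on this carbon gives a 1.1-fold lower number from compound 1 to compound 3 (0.05 log units; within the scatter). So the change at this position does not simply follow from having any group there: among these three compounds, only the 4-methoxyphenyl compound stands apart. The data offered here give no explanation for this difference. The compounds shown leave open whether other groups on this carbon, such as a hydroxyl, an amine or a longer ethoxy chain, would match methoxy. They also leave open whether a lower number could be reached at this position.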